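The source may report more compounds than this note shows. Statements on the series, on what has been measured and on what is new or still open speak of the compounds shown alone.

In a functional assay on CWR22R cells (Homo sapiens) for inhibition, read by WST assay, with a stated time of 3 days (a lower number here means a stronger inhibitor, a higher number a weaker inhibitor), compound 1 `Cc1ncsc1-c1ccc(CNC(=O)[C@@H]2C[C@@H](O)CN2C(=O)[C@@H](NC(=O)COCCOCCn2cc(CCOc3ccc(Cl)cc3C(=O)Nc3ccc([N+](=O)[O-])cc3Cl)nn2)C(C)(C)C)cc1` gives 6880 nM. Compound 2 `O=C(O)COCCOCCOc1ccc(Cl)cc1C(=O)Nc1ccc([N+](=O)[O-])cc1Cl` returns only a limit in this assay, > 10000 nM, and so stands at the limit of > 10000 nM in this assay, at which 1 of the 2 values shown sits, rather than at a number. Compound 3 `C#CCCOc1ccc(Cl)cc1C(=O)Nc1ccc([N+](=O)[O-])cc1Cl` carries ethynyl in place of 2-(carboxymethoxy)ethoxy on a saturated chain carbon, two bonds along the chain from an oxygen on an aromatic ring. No measured step links any pair of these compounds, and the two values shown give no direction for this change beyond a weak reading on either side. The step that the limit leaves unreadable from compound 2 to compound 3 is expected to fall within the scatter, with a limit again the likelier outcome. Compound 3 is expected near 12000 nM, in a range from 4000 nM to 40000 nM.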

Compound 3, half-maximal inhibitory concentration: > 10000 nM
Compound 3 gave a limit, no number; the forecaster's own chance of this, stated with the estimate: 60%; the middle value does not contradict the limit.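

Among the compounds shown here, compound 2 and compound 3 each return only a limit in this assay, so no step between them can be read: the limit of > 10000 nM in this assay, at which 2 of the 3 values shown sit. Going by these compounds, whether ethynyl in place of 2-(carboxymethoxy)ethoxy changes inhibition at all, and in which direction, stays open.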